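This account rests on a few compounds, and the source may have more. Where it says the series, first, only, none or still open, it means among the compounds named here.

In a physicochemical assay for lipophilicity, at pH 7.4 (on this read-out higher numbers stand for higher lipophilicity and lower numbers for lower lipophilicity), the three measured compounds gave the following:

Compound 1 `c1ccc(NC2=NCCC3(CCCCC3)S2)cc1`: 1.69
Compound 2 `CCNC1=NCCC2(CCCCC2)S1`: 0.72
Compound 3 `CNC1=NCCC2(CCCCC2)S1`: 0.91

Compound 1 stands highest of the three; the nearest gap is a number 0.78 log units lower from compound 1 to compound 3 (beyond the scatter) and the widest is a number 0.97 log units lower from compound 1 to compound 2 (beyond the scatter). Compound 4 `COc1ccc(NC2=NCCC3(CCCCC3)S2)cc1` keeps the phenyl of compound 1 and carries one change: methoxy in place of hydrogen on an aromatic carbon, para to a large group. Among the measured compounds shown here, no measured step bears directly on this change; the steps away from compound 1 swap the phenyl for an alkyl group, and a number 0.19 log units higher from compound 2 to compound 3 (within the scatter) alters the chain length only. For the measured compounds named here, with no guiding step, compound 1 is the sole anchor, and the expected step of a number 0.04 log units lower from compound 1 to compound 4 (within the scatter) is small and within the scatter. Compound 4 is therefore estimated at 1.65, in the range 1.3 to 2.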

Compound 4, distribution coefficient: 1.45
Beside the measured number, compound 4's estimate is 0.20 log units above it, within the range that was stated.
By their numbers in this assay, from the lowest: compounds 2 and 3 (each within the scatter of the next); then compounds 4 and 1 (each within the scatter of the next).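

On the phenyl itself, methoxy in place of hydrogen on an aromatic carbon, para to a large group, gives a number 0.24 log units lower from compound 1 to compound 4 (within the scatter) in this assay. Compound 4 and compound 1 therefore cannot be told apart on this read-out, whereas replacing the whole phenyl with ethyl or methyl gave steps beyond the scatter. Nothing shown explains this result.

As far as these compounds go, whether a carboxylic acid or an amine at this position would stay as close to compound 1 remains open. So does the outcome of methoxy on the other aromatic carbons.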